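The compounds below may be only part of what the source reports. "The series", "measured", "known", "first", "only" and "open" are said of these compounds alone.

Measured so far, in a functional assay on the whole organism (strain Wistar) for inhibition, with Rattus norvegicus as the target, read by paw edema, with stated times of 1 h and 3 h, at a dose of 10 mg/kg by the intraperitoneal route; a lower number here means less inhibition, a higher number more inhibition at the dose given (going by the name of the read-out):

compound 1, `COc1cc(/C=C/C(=O)/C=C(O)/C=C/c2ccc(OC(=O)[C@H](C)NC(=O)OC(C)(C)C)c(OC)c2)ccc1OC(=O)[C@H](C)NC(=O)OC(C)(C)C`: 20%
compound 2, `COc1cc(/C=C/C(=O)/C=C(O)/C=C/c2ccc(OC(=O)[C@@H](C)NC(=O)OC(C)(C)C)c(OC)c2)ccc1OC(=O)[C@@H](C)NC(=O)OC(C)(C)C`: 39%

Compound 2 stands highest of the two numbers; its nearest neighbour is compound 1, and the step of a number 19 percentage points higher from compound 1 to compound 2 (beyond the scatter) is the only one on record. That step rests on configuration alone, because of the fact that compounds 1 and 2 differ only in the configuration as drawn. The next compound, compound 3, `COc1cc(/C=C/C(=O)/C=C(O)/C=C/c2ccc(OC(=O)C(C)NC(=O)OC(C)(C)C)c(OC)c2)ccc1OC(=O)C(C)NC(=O)OC(C)(C)C`, is not yet measured. Against compound 2 it shows the following change: the two compounds have the same atoms and bonds; at least one stereo element is drawn with a configuration in one of them and without one in the other: 2 of 5 stereo elements differ; a stereocentre at a saturated chain carbon is drawn R in compound 2 and without a configuration in compound 3; a stereocentre at a saturated chain carbon is drawn R in compound 2 and without a configuration in compound 3. No atoms leave or enter; only the two drawn centres lose their configuration. For the measured compounds named here, the one measured step that bears on this is the configurational step from compound 1 to compound 2, which was modest but beyond the scatter. A compound drawn without configuration at those two centres is expected to fall somewhere between the two measured numbers rather than beyond either, so the expected step of a number 9 percentage points lower from compound 2 to compound 3 (within the scatter) is downward and likely within or near the scatter. In this assay compound 3 is therefore estimated at 30%, with a range from 17% to 43%.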

Compound 3, a percentage reported as inhibition, in the whole organism at one dose (the size of the read-out at that dose, not a potency): 25%
Estimate against measurement, compound 3: 5 percentage points above, and the stated range covers the measured number.
By their numbers in this assay, from the lowest: compounds 1 and 3 (each within the scatter of the next); then compound 2.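

In this assay, the two saturated chain stereocentres lose their drawn configuration in a number 14 percentage points lower from compound 2 to compound 3 (beyond the scatter), whereas the same loss gives a number 5 percentage points higher from compound 1 to compound 3 (within the scatter). For the compounds shown here, of the three compounds, only compound 2, drawn R at both centres, has steps to both others that are printed as beyond the scatter, so the R drawing is what sets one compound apart, while the compound without drawn configuration does not separate from the one drawn S. Both new comparisons keep the same atoms and bonds, so the configuration as drawn is the only thing that changes at this position: the fact that one of compounds 1 and 3 is drawn with a defined configuration and the other without, at the place where they differ; the same holds for the other pair: the fact that one of compounds 2 and 3 is drawn with a defined configuration and the other without, at the place where they differ.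

The two centres change together in every pair shown, so the share of each centre in these steps stays open, as does what the drawing without configuration stands for in the tested sample. Also open, going by these compounds, is whether the gap between the R and S drawings persists with a free amine in place of the carbamate, or with a longer chain in place of the methyl on the stereocentre.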